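This account rests on a few compounds, and the source may have more. Where it says the series, first, only, none or still open, it means among the compounds named here.

Compound 1 `CCCCOC(=O)C(O)Cn1cnc2c(N)ncnc21` gives 200 ug/mL in a functional assay on Vero cells (Chlorocebus sabaeus) for cytotoxicity; a higher number here means that more compound is tolerated, a lower number that less compound is tolerated. Compound 2 `CCCOC(=O)C(O)Cn1cnc2c(N)ncnc21` is reported in this assay only as a limit, > 400 ug/mL, not as a number. The step of an at least 2.0-fold higher number from compound 1 to compound 2 (0.30 log units; that floor lies within the scatter) therefore rests on the limit of > 400 ug/mL in this assay, at which 1 of the 2 values shown sits, and cannot be sized further. Compound 3 `CC(C)(C)OC(=O)C(O)Cn1cnc2c(N)ncnc21` differs from compound 2 by tert-butyl in place of propyl on an oxygen next to a carbonyl group. Going by the values given here, no measured step covers an exchange of this kind: the one step in hand replaces a methyl on the chain by hydrogen, whereas here the whole propyl is exchanged for tert-butyl. Both values in hand, for compound 1 and for compound 2, sit high in this assay, and compound 3 is expected to remain in that region, without a clear reason to exceed the limit seen for compound 2. The step expected from this change is an at least 1.3-fold lower number from compound 2 to compound 3 (0.12 log units; that floor lies within the scatter). Compound 3 is accordingly estimated at 300 ug/mL in this assay, within 150 ug/mL to 600 ug/mL.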

Compound 3, minimum cytotoxic concentration: > 400 ug/mL
Compound 3: no number, only a limit; the forecaster's own chance of this, stated with the estimate: 40%; middle value at least 1.3-fold (0.12 log units) away from the limit.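

In this assay compound 3 is reported only as a limit, > 400 ug/mL, not as a number. Exchanging butyl for tert-butyl gives an at least 2.0-fold higher number from compound 1 to compound 3 (0.30 log units; that floor lies within the scatter), so the floor seen earlier only with propyl now also holds for tert-butyl on an oxygen next to a carbonyl group. Compound 2 and compound 3 both stand as limits, so the step between them cannot be read, and most of the values shown now sit at one limit: the limit of > 400 ug/mL in this assay, at which 2 of the 3 values shown sit.

From the compounds shown here alone, how propyl and tert-butyl truly rank stays open, as does the size of any difference from butyl beyond the floor. Also open, going by these compounds, is how this assay responds to a longer chain such as hexyl, or to a free carboxylic acid in place of the ester.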